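From 2-methylphenyl to pyridin-2-yl in K562 cells

The source may report more compounds than this note shows. Statements on the series, on what has been measured and on what is new or still open speak of the compounds shown alone.

In a functional assay on K562 cells (Homo sapiens) for cytotoxicity, read by ELISA, with a stated time of 4 days (on this read-out higher numbers stand for weaker inhibition and lower numbers for stronger inhibition), compound 1 (`Cc1ccsc1-c1cc(-c2ccoc2)cc(-c2ccc(Cl)cc2)n1`) gives 19600 nM and compound 2 (`Clc1ccc(-c2cc(-c3ccco3)cc(-c3ccc(Cl)s3)n2)cc1`) gives 10500 nM while compound 3 (`Cc1ccccc1-c1cc(-c2ccoc2)cc(-c2ccc(Cl)s2)n1`) gives 12300 nM on the same read-out. Compound 3 thus lies within the usual scatter of both other compounds, and these numbers set no order among them. Compound 4 (`Clc1ccc(-c2cc(-c3ccoc3)cc(-c3ccccn3)n2)s1`) carries pyridin-2-yl in place of 2-methylphenyl on an aromatic carbon and has not yet been measured. Among the measured compounds shown here, no measured pair isolates this change, so no step beyond the scatter is expected in this assay in either direction. The estimated change is a 1.1-fold lower number from compound 3 to compound 4 (0.05 log units; within the scatter) and stays within the scatter. Compound 4 is expected at 11000 nM with an estimated range (4500 nM to 26000 nM).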

Compound 4, half-maximal inhibitory concentration: 20000 nM
Beside the measured number, compound 4's estimate is 1.8-fold (0.26 log units) below it; the measured number falls inside the stated range.
By their numbers in this assay, from the lowest: compounds 2, 3, 1 and 4 (each within the scatter of the next).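

In this assay, replacing 2-methylphenyl with pyridin-2-yl on this aromatic carbon, next to the ring nitrogen, gives a 1.6-fold higher number from compound 3 to compound 4 (0.21 log units; within the scatter), and this is the only pair shown that differs in one place. With 5-chlorothiophen-2-yl and furan-3-yl held constant, the swap to a ring with one hydrogen-bond acceptor therefore sets no order between the two compounds. No evidence on hand bears on this result. As far as these compounds go, whether an amine or a carboxylic acid on the pyridin-2-yl ring would take the number beyond the scatter remains open. So does whether the same swap would behave alike with a phenyl group in place of furan-3-yl.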